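The source may report more compounds than this note shows. Statements on the series, on what has been measured and on what is new or still open speak of the compounds shown alone.

Measured so far in a functional assay on B16-F10 cells (Mus musculus) for antiproliferative activity, read by MTT assay, with a stated time of 72 h; on this read-out lower numbers stand for stronger inhibition and higher numbers for weaker inhibition:
compound 1 `O=C1Nc2ccccc2/C1=C1/Cc2ccccc2C1=O`: > 100000 nM
compound 2 `O=C1Nc2ccc(Br)cc2/C1=C1/Cc2ccccc2C1=O`: 69100 nM
compound 3 `O=C1NC(=S)N/C1=C1\C(=O)Nc2ccccc21`: 41600 nM

The value of compound 1 is a limit of the assay rather than a number, (the limit of > 100000 nM in this assay, at which 1 of the 3 values shown sits). Compound 2 differs from compound 1 by bromo in place of hydrogen on an aromatic carbon; this gave an at least 1.4-fold lower number from compound 1 to compound 2 (0.16 log units; that floor lies within the scatter). Compound 3 has a different core from compound 1, and the difference between the two cores is not broken down here. The values of compound 3 and compound 2 lie within the scatter of each other, so no order between them is read.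

Compound 4 `O=C1NC(=S)N/C1=C1\C(=O)Nc2c(Br)cccc21` is not yet measured in this assay. It differs from compound 3 by bromo in place of hydrogen on an aromatic carbon. This is the same kind of change as that between compound 1 and compound 2, but the place is not identical: in the measured pair the bromo sits meta to a fused ring and para to a fused ring, whereas in compound 4 it sits ortho to a fused ring and meta to a fused ring. The expectation for compound 4 rests on the measured step, which was an at least 1.4-fold lower number from compound 1 to compound 2 (0.16 log units; that floor lies within the scatter), a small change, and on the different core of compound 3. Compound 4 is expected to show a 1.4-fold lower number from compound 3 to compound 4 (0.14 log units; within the scatter) in this assay. Compound 4 is estimated at 30000 nM, expected to fall between 10000 nM and 90000 nM.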

Compound 4, half-maximal inhibitory concentration: 5000 nM
The estimate for compound 4 lay 6.0-fold (0.78 log units) above the measured number, and the stated range ends above it.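

On the core of compound 3, bromo in place of hydrogen on an aromatic carbon, ortho to a fused ring and meta to a fused ring, gave an 8.3-fold lower number from compound 3 to compound 4 (0.92 log units; beyond the scatter) in this assay, so the change lowers the number on this core. Compound 1 stands at a limit of the assay, not at a number: the limit of > 100000 nM in this assay, at which 1 of the 4 values shown sits. Set side by side, the two steps do not show whether the change carries from one core to the other with the same size, and the bromo also sits at a different place in the two pairs, so core and place cannot be separated: the same change on two cores in this assay, an at least 1.4-fold lower number (0.16 log units; that floor lies within the scatter) from compound 1 to compound 2 and an 8.3-fold lower number (0.92 log units; beyond the scatter) from compound 3 to compound 4; the limit leaves it open whether they differ.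

Still open, as far as these compounds go, is whether bromo at the place it holds in compound 4 gives a step of like size on the core of compound 1, and whether the core of compound 3 responds the same way to bromo at the place it holds in compound 2. Also open, from the compounds shown here alone, is what a different group at these places, such as a methoxy, an amine or a carboxylic acid, would do.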